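Carbamoyl for allyl on the chain at the aromatic nitrogen

The compounds below may be only part of what the source reports. "The series", "measured", "known", "first", "only" and "open" are said of these compounds alone.

Of the compounds shown here, three that share one core have been measured in an assay on Cerebral cortex for binding affinity to adenosine receptor A1 (Cavia porcellus), read by radioligand binding; on this read-out lower numbers stand for stronger inhibition and higher numbers for weaker inhibition. Compound 1 `CCCn1c(=O)n(CCCN(C)C)c(=O)c2[nH]cnc21` gives 43200 nM, compound 2 `CCCn1c(=O)n(CCOC)c(=O)c2[nH]cnc21` gives 2500 nM, and compound 3 `C=CCCn1cnc2c1c(=O)n(C)c(=O)n2CCC` gives 6000 nM. Compound 3 therefore stands second highest of the three numbers: its nearest neighbour is compound 2, with a lower number beyond the scatter, while compound 1 lies furthest away with a higher number, also beyond the scatter.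

Compound 4 `CCCn1c(=O)n(C)c(=O)c2c1ncn2CC(N)=O` differs from compound 3 in one place: carbamoyl in place of allyl on a saturated chain carbon bound to an aromatic nitrogen. Among the compounds with values here, the only measured step with a single change, a 17-fold lower number from compound 1 to compound 2 (1.24 log units; beyond the scatter), concerns a different chain on a different aromatic nitrogen, where methoxy replaced (dimethylamino)methyl, and it therefore bears only loosely on the present change. Within the data shown here, no measured pair shows a carbamoyl entering at the saturated chain carbon bound to the aromatic nitrogen carrying the allyl. Because compound 3 already sits at 6000 nM, a weakening step is expected, a 2.5-fold higher number from compound 3 to compound 4 (0.40 log units; beyond the scatter), with wide uncertainty. Compound 4 is thus estimated at 15000 nM, within a range from 4000 nM to 60000 nM.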

Compound 4, inhibition constant: > 200000 nM
Compound 4: no number, only a limit; the forecaster's own chance of this, stated with the estimate: 25%; at least 13-fold (1.12 log units) between middle value and limit.
By their numbers in this assay, from the lowest: compound 2; then compound 3; then compound 1. At a limit, above all of these: compound 4.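

In this assay, carbamoyl in place of allyl on a saturated chain carbon bound to an aromatic nitrogen gives an at least 33-fold higher number from compound 3 to compound 4 (1.52 log units; beyond the scatter), so the chain at this position proves highly sensitive to what it carries. Compound 4 yields no number, only a limit of the assay: the limit of > 200000 nM in this assay, at which 1 of the 4 values shown sits. Within the data shown here, the one earlier single change, a 17-fold lower number from compound 1 to compound 2 (1.24 log units; beyond the scatter), lay on a different chain at a different aromatic nitrogen, whereas this step shows a large response at this position too, and it does so with the same count of heavy atoms and of double bonds outside aromatic rings in the group that leaves and the group that enters, the counts differing only in the hydrogen-bond donor and acceptor that carbamoyl brings.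

The compounds shown leave open whether the loss follows from the arrival of carbamoyl or from the departure of allyl, and whether a saturated butyl chain, a methyl ester or an amine at the same place would stay close to compound 3. On these data alone, how far the true value of compound 4 lies past its limit also stays unknown.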